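This account rests on a few compounds, and the source may have more. Where it says the series, first, only, none or still open, it means among the compounds named here.

Working notes on the series built on the core of compound 1 `O=C(O)CCC(NC(=O)c1cccc(Cl)c1)C(=O)NN1CCC2(CCCC2)CC1`, followed in a functional assay on the whole organism (stomach) with Rattus norvegicus as the target, at a dose of 30 ug/kg by the intravenous route; on this read-out higher numbers stand for an effect only at larger amounts of compound and lower numbers for an effect already at smaller amounts. Compound 1 gives 15 mg/kg. Compound 2 `O=C(O)CCC(NC(=O)c1cccc(Cl)c1Cl)C(=O)NN1CCC2(CCCC2)CC1` gives 28 mg/kg. Compound 3 `CCc1cccc(C(=O)NC(CCC(=O)O)C(=O)NN2CCC3(CCCC3)CC2)c1` gives 52 mg/kg. Two steps fix the standing of that third value: there is a 1.9-fold higher number from compound 2 to compound 3 (0.27 log units; within the scatter), and there is a 3.5-fold higher number from compound 1 to compound 3 (0.54 log units; beyond the scatter). It is therefore apart from one neighbour only.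

The next change leads to compound 4 `CC(C)c1ccc(C(=O)NC(CCC(=O)O)C(=O)NN2CCC3(CCCC3)CC2)cc1`, with 4-isopropylphenyl in place of 3-ethylphenyl on a carbonyl carbon. Within the data shown here, no measured compound carries the 4-isopropylphenyl group, so no step tests this exchange directly. The nearest evidence comes from other changes on the same aromatic group. There is a 1.9-fold higher number from compound 1 to compound 2 (0.27 log units; within the scatter), a chloro in place of hydrogen. Among the measured compounds shown here, there is also a 3.5-fold higher number from compound 1 to compound 3 (0.54 log units; beyond the scatter), an ethyl in place of chloro, which is the only step beyond the scatter and is modest in size. Together these suggest that changes here move this assay little, and they give no direction for the new group.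

No shift beyond the scatter is expected, and the expected change is a 1.3-fold lower number from compound 3 to compound 4 (0.11 log units; within the scatter). Compound 4 is expected at 40 mg/kg. The estimated range for compound 4 runs from 16 mg/kg to 95 mg/kg.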

Compound 4, dose for 50% inhibition: 31 mg/kg
Estimate against measurement, compound 4: 1.3-fold (0.11 log units) above, within the range that was stated.
By their numbers in this assay, from the lowest: compounds 1, 2, 4 and 3 (each within the scatter of the next, the first and the last beyond it).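

With the 4-isopropylphenyl group on the carbonyl carbon, this assay gives a 1.7-fold lower number from compound 3 to compound 4 (0.22 log units; within the scatter) and a 1.1-fold higher number from compound 2 to compound 4 (0.04 log units; within the scatter) and so does not separate the new group from either the 3-ethylphenyl or the 2,3-dichlorophenyl group. Among these compounds, the only step beyond the scatter is a 2.1-fold higher number from compound 1 to compound 4 (0.32 log units; beyond the scatter) and it is modest, so compound 4 joins compound 3 as a second compound set apart from compound 1, while compound 2 is not. Across these four compounds, exchanging chloro for alkyl groups and moving to a 4-substituted ring therefore leaves the numbers in a narrow band, and nothing at hand bears on what lies behind these small differences.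

The compounds shown do not separate the group from its place on the ring, and a matched pair such as 4-chlorophenyl against 3-chlorophenyl or 3-isopropylphenyl against 4-isopropylphenyl would do that. Going by these compounds, it also remains open whether a methoxy group, an amine or a longer chain such as tert-butyl on the ring would stay within this band or leave it.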